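Methylamino for methylsulfanyl on the phenyl compound

This account rests on a few compounds, and the source may have more. Where it says the series, first, only, none or still open, it means among the compounds named here.

Values in an ADME assay on BJ cells (Homo sapiens), read by MTT assay, with a stated time of 72 h; on this read-out higher numbers stand for weaker inhibition and lower numbers for stronger inhibition:
- compound 1 `CSc1ncnc2c1c(-c1ccsc1)cn2[C@@H]1O[C@H](CO)[C@@H](O)[C@H]1O`: 95800 nM
- compound 2 `CSc1ncnc2c1c(-c1ccccc1)cn2[C@@H]1O[C@H](CO)[C@@H](O)[C@H]1O`: > 100000 nM
- compound 3 `C#Cc1cn([C@@H]2O[C@H](CO)[C@@H](O)[C@H]2O)c2ncnc(SC)c12`: 68600 nM

All three compounds carry methylsulfanyl and sit at high numbers in this assay. Compound 2 gives no number at all, and its > 100000 nM is a limit of the assay, as the limit of > 100000 nM in this assay, at which 1 of the 3 values shown sits, shows. Its true position is therefore open on the upper side.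

The next compound is compound 4 `CNc1ncnc2c1c(-c1ccccc1)cn2[C@@H]1O[C@H](CO)[C@@H](O)[C@H]1O`, which has methylamino in place of methylsulfanyl on an aromatic carbon, next to the ring nitrogen: methylamino in place of methylsulfanyl on an aromatic carbon. For the measured compounds named here, no measured pair makes this exchange. The measured steps all alter the other substituent and leave methylsulfanyl untouched. They are an at least 1.0-fold higher number from compound 1 to compound 2 (0.01 log units; that floor lies within the scatter), a 1.4-fold lower number from compound 1 to compound 3 (0.15 log units; within the scatter) and an at least 1.4-fold lower number from compound 2 to compound 3 (0.16 log units; that floor lies within the scatter). Each is small, so they show a series insensitive to that substituent, but they say only indirectly how the new group will behave.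

With so little direct evidence, the expectation stays modest and is held loosely. A small move towards a lower number is expected, given as an at least 1.6-fold lower number from compound 2 to compound 4 (0.22 log units; that floor lies within the scatter). For compound 4 the estimated value is 60000 nM, with an expected range from 10000 nM to 100000 nM.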

Compound 4, half-maximal inhibitory concentration: > 100000 nM
Compound 4 was reported as a limit; the forecaster's own chance of this, stated with the estimate: 40%; middle value at least 1.6-fold (0.22 log units) away from the limit.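

Compound 2 and compound 4 both sit at a limit in this assay, not at a number, so no step can be read between them: the limit of > 100000 nM in this assay, at which 2 of the 4 values shown sit.

The compounds shown leave open how methylamino compares with methylsulfanyl on the shared core in this assay, in both the direction and the size of any difference.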